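Changing the Group on the Ring Nitrogen of Compound 3

This account rests on a few compounds, and the source may have more. Where it says the series, first, only, none or still open, it means among the compounds named here.

Of the compounds shown here, three share one core and have been measured in a functional assay on SGC-7901 cells (Homo sapiens) for inhibition, read by MTT assay, with a stated time of 72 h; on this read-out lower numbers stand for stronger inhibition of growth and higher numbers for weaker inhibition of growth. Going by the values given here, compound 1 `COC1=C(C)C(=O)C(CCCCCCCCCCn2cc(C[C@H](O)COCCOC[C@@H](O)Cc3ccc(-c4ccccc4)cc3)nn2)=C(C)C1=O` gives 505 nM, and compound 2 `COC1=C(OC)C(=O)C(CCCCCCCCCCn2cc(C[C@H](O)COCCOC[C@@H](O)Cc3ccc(-c4ccccc4)cc3)nn2)=C(C)C1=O` gives 3800 nM; the only single-point step among them is a 7.5-fold higher number from compound 1 to compound 2 (0.88 log units; beyond the scatter). Compound 3 `O[C@H](COCCOC[C@@H](O)Cc1cn(-c2cccs2)nn1)Cc1ccc(-c2ccccc2)cc1` gives 33400 nM, the highest of the three numbers, so on these values it is the weakest inhibitor of growth.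

Compound 4 `N#Cc1ccc(Cn2cc(C[C@H](O)COCCOC[C@@H](O)Cc3ccc(-c4ccccc4)cc3)nn2)cc1` differs from compound 3 in one place: 4-cyanobenzyl in place of thiophen-2-yl on an aromatic nitrogen. Among the compounds with values here, no measured step concerns this position. The step from compound 1 to compound 2 changes a methoxy for a methyl elsewhere, on a part that compound 3 and compound 4 do not carry, so it says nothing about what a 4-cyanobenzyl does in place of thiophen-2-yl. Without guidance, the expected change a 1.7-fold lower number from compound 3 to compound 4 (0.22 log units; within the scatter) is small and uncertain. Compound 4 is estimated at 20000 nM, with a range from 6000 nM to 60000 nM.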

Compound 4, concentration for 50% growth inhibition: 7700 nM
Compound 4: middle estimate off by 2.6-fold (0.41 log units), on the high side; low and high end bracket the measured number.
By their numbers in this assay, from the lowest: compound 1; then compound 2; then compound 4; then compound 3.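

Placing 4-cyanobenzyl instead of thiophen-2-yl on this aromatic nitrogen gives a 4.3-fold lower number from compound 3 to compound 4 (0.64 log units; beyond the scatter) in this assay, so the number in this test does respond to the group at this position. The swap replaces a five-membered aromatic ring holding sulfur with a six-membered aromatic ring of carbon only that carries a nitrile, so several features change in one step. Nothing available here tests why the number falls, and this single step cannot assign the change to any one of those features.

A plain benzyl group on the same nitrogen would show how much of the step depends on the nitrile. Also open, from the compounds shown here alone, is how the number would respond to an amine or a carboxylic acid in place of that nitrile.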